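Notes on amide-nitrogen variation in a methoxyquinoline series

This account rests on a few compounds, and the source may have more. Where it says the series, first, only, none or still open, it means among the compounds named here.

Measured so far:
compound 1 `COc1ccc2cccc(CCC(=O)NS(C)(=O)=O)c2n1` — 0.03 nM
compound 2 `CCS(=O)(=O)NC(=O)CCc1cccc2ccc(OC)nc12` — 1 nM

Among the compounds with values here, compound 2 stands at the higher of the two numbers in an assay on cells for displacement of a labelled ligand from melatonin receptor type 1B (Homo sapiens), with a stated time of 120 min; on this read-out lower numbers stand for stronger inhibition and higher numbers for weaker inhibition; its only neighbour is compound 1, and the step of a 33-fold higher number from compound 1 to compound 2 (1.52 log units; beyond the scatter) is large and lies beyond the scatter. Compound 3 `COc1ccc2cccc(CCC(=O)NC3CC3)c2n1` is not yet measured. Relative to compound 2 the change is cyclopropyl in place of ethylsulfonyl on an amide-type nitrogen: the acylsulfonamide is given up for a plain secondary amide.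

Within the data shown here, no measured step covers this change. Among the measured compounds shown here, the one step that touches the same nitrogen substituent, a 33-fold higher number from compound 1 to compound 2 (1.52 log units; beyond the scatter), shows that even a small change there moves this assay a long way, so a sizeable step is expected for compound 3, but its direction cannot be read from the two measured compounds. On balance compound 3 is expected to give about 3 nM in this assay, a step of a 3.0-fold higher number from compound 2 to compound 3 (0.48 log units; beyond the scatter), with a wide range from 0.1 nM to 100 nM.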

Compound 3, inhibition constant: 0.5 nM
For compound 3 the middle estimate is 6.0-fold (0.78 log units) above the measured one; the range from low to high includes it.
By their numbers in this assay, from the lowest: compound 1; then compounds 3 and 2 (each within the scatter of the next).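

In this assay, the sulfonyl group is not required for a number in the range of compound 2: replacing ethylsulfonyl with cyclopropyl gives a 2.0-fold lower number from compound 2 to compound 3 (0.30 log units; within the scatter). Replacing methylsulfonyl with the same cyclopropyl gives a large step, a 17-fold higher number from compound 1 to compound 3 (1.22 log units; beyond the scatter), so among these three compounds only the methylsulfonyl group of compound 1 stands apart, and the acylsulfonamide as such does not set the low number. Nothing available accounts for either step.

The compounds shown leave open whether a plain methyl on the same nitrogen would reach the number of compound 1 without the sulfonyl. They also leave open how cyclobutyl or a longer alkyl chain on that nitrogen would compare with cyclopropyl.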